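This account rests on a few compounds, and the source may have more. Where it says the series, first, only, none or still open, it means among the compounds named here.

Of the compounds shown here, three have so far been tested in a functional assay on MDA-MB-231 cells (Homo sapiens) for antiproliferative activity, read by MTT assay, with a stated time of 72 h; a lower number here means a stronger inhibitor, a higher number a weaker inhibitor. Compound 1 `Cn1ncnc1-c1cc(Oc2ccc(NC(=O)Nc3cccc(C(F)(F)F)c3)cc2F)ccn1` gives 9680 nM. Compound 2 `Cn1cnnc1-c1cc(Oc2ccc(NC(=O)Nc3cccc(C(F)(F)F)c3)cc2F)ccn1` gives 6470 nM, and the step of a 1.5-fold lower number from compound 1 to compound 2 (0.17 log units; within the scatter) is one that repeated measurements could not tell from chance. Compound 3 `CCN(CC)CCn1cnnc1-c1cc(Oc2ccc(NC(=O)Nc3cccc(C(F)(F)F)c3)cc2F)ccn1` gives 720 nM, the lowest of the three numbers; the steps of a 13-fold lower number from compound 1 to compound 3 (1.13 log units; beyond the scatter) and a 9.0-fold lower number from compound 2 to compound 3 (0.95 log units; beyond the scatter) both lie beyond the scatter, so compound 3 stands clearly apart as the strongest inhibitor measured so far.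

Compound 4 `CCN(CC)CCn1cnnc1-c1cc(Oc2ccc(NC(=O)Nc3ccc(Cl)cc3Cl)cc2F)ccn1` has not yet been measured. It differs from compound 3 in a single place: 2,4-dichlorophenyl in place of 3-(trifluoromethyl)phenyl on an amide-type nitrogen. Among the compounds with values here, none of the three measured steps touches this part of the molecule; all of them concern the group on the other side of the shared core, so no measured step bears on this change, and there is nothing to point in either direction. With no guide from the measured steps, the expectation is that compound 4 will show a change a 1.0-fold higher number from compound 3 to compound 4 (0.02 log units; within the scatter) that stays within the scatter. Compound 4 is therefore estimated at 750 nM in this assay, with a range from 250 nM to 2500 nM.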

Compound 4, half-maximal inhibitory concentration: 1790 nM
Beside the measured number, compound 4's estimate is 2.4-fold (0.38 log units) below it, and the stated range covers the measured number.
By their numbers in this assay, from the lowest: compound 3; then compound 4; then compounds 2 and 1 (each within the scatter of the next).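

The aryl group on the amide-type nitrogen turns out to matter for activity: in this assay, the swap of 3-(trifluoromethyl)phenyl for 2,4-dichlorophenyl gives a 2.5-fold higher number from compound 3 to compound 4 (0.40 log units; beyond the scatter). Within the data shown here, this is the first measured change on this side of the molecule, and the step lies beyond the scatter, though it is modest in size. The change replaces one trifluoromethyl group with two chlorine atoms in a single move, and nothing available explains why the number rises.

The pair cannot show whether the rise comes from having two chlorines, from where they sit, or from losing the trifluoromethyl group. A plain phenyl or a phenyl carrying a single chlorine on this nitrogen would help separate these possibilities.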